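From Chloro to Bromo on an Aromatic Carbon

The compounds below may be only part of what the source reports. "The series", "measured", "known", "first", "only" and "open" are said of these compounds alone.

For the measured compounds named here, compound 2 `O=c1cc(-c2ccc(Cl)cc2)oc2cc(O)cc(O)c12` gives 16000 nM in an ADME assay on H9 cells (Homo sapiens) for cytotoxicity, with a stated time of 3 days (a lower number here means a stronger inhibitor, a higher number a weaker inhibitor), the higher of the two numbers seen so far, though within the scatter of its only neighbour. That neighbour, compound 1 `O=c1cc(-c2ccc(F)cc2)oc2cc(O)cc(O)c12`, gives 13000 nM in this assay. Compound 3 `O=c1cc(-c2ccc(Br)cc2)oc2cc(O)cc(O)c12` differs from compound 2 by a single change: bromo in place of chloro on an aromatic carbon. Going by the values given here, the one earlier step that resembles it, a halogen swap on the same carbon, is a 1.2-fold higher number from compound 1 to compound 2 (0.09 log units; within the scatter). Because that step stayed within the scatter, the expected step here is a 1.1-fold higher number from compound 2 to compound 3 (0.05 log units; within the scatter), nothing beyond the scatter. Compound 3 is therefore estimated at 18000 nM, with a range from 8000 nM to 40000 nM.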

Compound 3, half-maximal inhibitory concentration: 21000 nM
Compound 3: the middle estimate sits 1.2-fold (0.07 log units) below what was measured; low and high end bracket the measured number.
By their numbers in this assay, from the lowest: compounds 1, 2 and 3 (each within the scatter of the next).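

In this assay this carbon has now carried fluoro, chloro and bromo, and the swap to bromo gives a 1.3-fold higher number from compound 2 to compound 3 (0.12 log units; within the scatter), while the swap from fluoro to bromo gives a 1.6-fold higher number from compound 1 to compound 3 (0.21 log units; within the scatter). Across these three halogens, then, no swap shown at this carbon moves the number beyond the scatter. Nothing available explains why these numbers stay so close. Still open, as far as these compounds go, is whether a group of another kind at this carbon, such as an amine or a carboxylic acid, would give a number clearly apart from these halogens.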